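A few compounds are considered here, and "the series" means these few. Any claim that something is new, unique, unknown or untested is made for them only; others in the source may bear on it.

Measured compounds in a functional assay on HEK293 cells for agonist activity at Free fatty acid receptor 1 (Homo sapiens), read by FLIPR and calcium flux; on this read-out lower numbers stand for an effect already at smaller amounts and higher numbers for an effect only at larger amounts of compound:
compound 1 `COc1ccc(F)c([C@H]2CC[C@H](COc3cccc([C@@H](CC(=O)O)C4CC4)c3)CC2)c1` gives 0.94 nM
compound 2 `COc1ccc(F)c([C@H]2CC[C@H](COc3cccc([C@H](C4CC4)[C@H](C)C(=O)O)c3)CC2)c1` gives 0.2 nM
compound 3 `COc1ccc(F)c([C@H]2CC[C@H](COc3cccc([C@H](C4CC4)[C@@H](C)C(=O)O)c3)CC2)c1` gives 2.2 nM

Compound 3 stands at the highest number of the three. Its nearest neighbour is compound 1, with a 2.3-fold higher number from compound 1 to compound 3 (0.37 log units; beyond the scatter), and its furthest is compound 2, with an 11-fold higher number from compound 2 to compound 3 (1.04 log units; beyond the scatter); that last step arises (the fact that compounds 2 and 3 differ only in the configuration as drawn).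

Compound 4 `COc1ccc(F)c([C@H]2CC[C@H](COc3cccc([C@H](C4CC4)[C@@](C)(F)C(=O)O)c3)CC2)c1` is reached from compound 3 by one change: fluoro in place of hydrogen on a saturated chain carbon bound to a carbonyl carbon and two saturated chain carbons.

For the measured compounds named here, no measured step adds a fluoro, so none bears directly on this change. What the measured steps do show is that this carbon is sensitive: adding a methyl there gave a 4.7-fold lower number from compound 1 to compound 2 (0.67 log units; beyond the scatter) in one arrangement and a 2.3-fold higher number from compound 1 to compound 3 (0.37 log units; beyond the scatter) in the other. A further substituent at the same carbon could therefore move the number in either direction. Going by the values given here, with no direct precedent, a step near the scatter is expected, a 1.4-fold higher number from compound 3 to compound 4 (0.13 log units; within the scatter), with wide uncertainty. For compound 4 the estimated value in this assay is 3 nM, within a range of 0.7 nM to 13 nM.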

Compound 4, half-maximal effective concentration: 0.25 nM
For compound 4 the middle estimate is 12-fold (1.08 log units) above the measured one, and the stated range ends above it.
By their numbers in this assay, from the lowest: compounds 2 and 4 (each within the scatter of the next); then compound 1; then compound 3.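

Until now this carbon had shown only what a methyl does, and compound 4 shows that a fluoro added with the methyl kept in place can also move the number substantially, with an 8.8-fold lower number from compound 3 to compound 4 (0.94 log units; beyond the scatter). That step is larger than either step seen on adding the methyl alone, and it removes the disadvantage of compound 3: the result is close to the other methyl arrangement, with a 1.3-fold higher number from compound 2 to compound 4 (0.10 log units; within the scatter), and it also improves on the parent without a methyl, with a 3.8-fold lower number from compound 1 to compound 4 (0.58 log units; beyond the scatter). Nothing available here explains why the fluoro acts in this way.

The compounds shown leave open what a fluoro would do in the arrangement of compound 2, or on compound 1 with no methyl present. They also leave open whether a chloro or a hydroxyl at this carbon would behave like the fluoro.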